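A few compounds are considered here, and "the series" means these few. Any claim that something is new, unique, unknown or untested is made for them only; others in the source may bear on it.

Measured in a functional assay on BaF3 cells (Mus musculus) for inhibition, read by CCK-8 assay, with a stated time of 72 h; on this read-out lower numbers stand for stronger inhibition of growth and higher numbers for weaker inhibition of growth:
- compound 1 `CC(=O)Nc1cc(Oc2ccc(NC(=O)Nc3ccc(CN4CCN(C)CC4)c(C(F)(F)F)c3)cc2)ncn1`: 50 nM
- compound 2 `CCN1CCN(Cc2ccc(NC(=O)Nc3ccc(Oc4cc(NC(C)=O)ncn4)cc3)cc2C(F)(F)F)CC1`: 38 nM
- compound 3 `Cc1ccc(NC(=O)Nc2ccc(Oc3cc(N)ncn3)cc2)cc1C(F)(F)F`: > 10000 nM, a limit

Compound 3 stands at a limit and not at a number: the limit of > 10000 nM in this assay, at which 1 of the 3 values shown sits.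

Compound 4 `Cc1ccc(NC(=O)Nc2ccc(Oc3cc(N4CCNC[C@@H]4C)ncn3)cc2)cc1C(F)(F)F` carries 2-methylpiperazin-1-yl in place of amino on an aromatic carbon. Going by the values given here, the one measured step, a 1.3-fold lower number from compound 1 to compound 2 (0.12 log units; within the scatter), lies elsewhere on the structure and bears little on this change. Among the compounds with values here, no measured step covers this place. Within the data shown here, compound 1 at 50 nM shows only that low numbers occur, and it differs from compound 3 in more than one place. The expected change is an at least 6.6-fold lower number from compound 3 to compound 4 (0.82 log units; beyond the scatter), towards stronger inhibition of growth, and its size is poorly bounded. For compound 4 the estimate is 1500 nM, with an expected range of 150 nM to 10000 nM.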

Compound 4, concentration for 50% growth inhibition: 8120 nM
Compound 4: middle estimate off by 5.4-fold (0.73 log units), on the low side; the range from low to high includes it.
By their numbers in this assay, from the lowest: compounds 2 and 1 (each within the scatter of the next); then compound 4. At a limit, above all of these: compound 3.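

Going by these compounds alone, replacing amino with 2-methylpiperazin-1-yl on this aromatic carbon gives the first measured step at this position in this assay: an at least 1.2-fold lower number from compound 3 to compound 4 (0.09 log units; that floor lies within the scatter). Compound 4 gives a numerical value of 8120 nM, so this larger ring-bearing group is compatible with measurable growth inhibition. The true size of the step remains unfixed, as compound 3 is at a limit: the limit of > 10000 nM in this assay, at which 1 of the 4 values shown sits.

Open, as far as these compounds go, is whether plain piperazin-1-yl, without the ring methyl, would read differently from compound 4. Also open, from the compounds shown here alone, is how morpholin-4-yl or dimethylamino at this carbon would compare.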